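Swapping a cyclohexyl tail for a pyridin-2-yl tail

The compounds below may be only part of what the source reports. "The series", "measured", "known", "first", "only" and "open" are said of these compounds alone.

Compound 1, `N#C/N=C(/NCCCc1c[nH]cn1)NCCCC1CCCCC1`, and compound 2, `N#C/N=C(/NCCCCc1c[nH]cn1)NCCCC1CCCCC1`, share one core and differ only in the length of the chain that carries the five-membered ring. In an in vitro functional assay on Sf9 cells for antagonist activity at histamine H2 receptor (Homo sapiens) (a lower number here means a less potent compound, a higher number a more potent compound, by a factor of ten per unit of this negative logarithm), compound 1 gives < 5; < 5 (2 entries), which is a limit of the assay rather than a number. In this assay compound 2 gives < 5, again a limit of the assay and not a number. Compound 2 therefore stands at the floor of what this test can report, with no single number of its own. Compound 3, `N#C/N=C(/NCCCCc1c[nH]cn1)NCCCc1ccccn1`, keeps the chain of compound 2 but carries pyridin-2-yl in place of cyclohexyl on a saturated chain carbon, three bonds along the chain from an amine nitrogen. For the measured compounds named here, no measured pair shows what this exchange does on its own. The expected step in this assay is modest and upward, a number at least 0.30 log units higher from compound 2 to compound 3 (that floor lies within the scatter), not safely beyond the usual scatter. Compound 3 is accordingly estimated at 5.3 in this assay, with a range from 4.5 to 6.2. A reading that is once more only a limit remains quite possible.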

Compound 3, negative logarithm of the antagonist equilibrium constant: 5.48
Compound 3: middle estimate off by 0.18 log units, on the low side, within the range that was stated.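

In this assay, putting pyridin-2-yl in place of cyclohexyl on a saturated chain carbon, three bonds along the chain from an amine nitrogen, gives a number at least 0.48 log units higher from compound 2 to compound 3 (beyond the scatter). For the compounds shown here, this shows that the tail at this position can move the reading, since compound 3 is the first compound here with a single number rather than a limit. The full size of the step cannot be read because its starting point is a limit, so the step has only a lower bound: the limit of < 5 in this assay, at which 1 of the 3 values shown sits.

Going by these compounds, it remains open whether the ring nitrogen matters, which a plain phenyl tail at the same place would test, and whether pyridin-3-yl or pyridin-4-yl would serve equally well. Also open, on these data alone, is what pyridin-2-yl would do on the shorter chain of compound 1.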